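The source may report more compounds than this note shows. Statements on the series, on what has been measured and on what is new or still open speak of the compounds shown alone.

In a functional assay with Oryctolagus cuniculus as the target (a lower number here means a stronger inhibitor, a higher number a weaker inhibitor), compound 1 `COc1ccc(-c2nc(N=C(N)N)sc2-c2ccc(OC)cc2)cc1` gives 31000 nM. Compound 2 `CC/N=C(/N)Nc1nc(-c2ccc(OC)cc2)c(-c2ccc(OC)cc2)s1` gives > 100 nM, which is a limit of the assay and not a number. Going by these compounds, compound 3 `COc1ccc(-c2nc(/N=C(\N)n3ccnc3)sc2-c2ccc(OC)cc2)cc1` gives > 100 nM, again only a limit, so its exact place on the scale stays open. Compound 4 `COc1ccc(-c2nc(CN)sc2-c2ccc(OC)cc2)cc1` has not yet been measured, and the structural change is a group of 2 heavy atoms (1 carbon, 1 nitrogen; no ring) in place of a group of 8 heavy atoms (4 carbon, 4 nitrogen; one five-membered aromatic ring with 2 hetero atoms), on an aromatic carbon. The entering group is aminomethyl. The measured steps that bear on this, a step that the limit leaves unreadable from compound 1 to compound 3 and a step that the two limits leave unreadable from compound 2 to compound 3, have no readable size, so they point to no size or direction. Among the measured compounds shown here, the one true number belongs to compound 1, at 31000 nM, and the estimate leans on it. The expected change is a step that the limit leaves unreadable from compound 3 to compound 4, held loosely. Compound 4 is expected at 15000 nM, with an estimated range of 1500 nM to 100000 nM.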

Compound 4, half-maximal inhibitory concentration: > 100 nM
Compound 4: only a limit was reported; the forecaster's own chance of this, stated with the estimate: 35%; the middle value lies beyond the limit too.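

Among the compounds shown here, the result for compound 4 is a limit of the assay and not a number, so no step linking compound 4 to compound 1, compound 2 or compound 3 can be read. The compounds shown leave open how strong compound 2, compound 3 and compound 4 really are, and what they share is this: the limit of > 100 nM in this assay, at which 3 of the 4 values shown sit.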